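Enlarging the side group of compound 2

The source may report more compounds than this note shows. Statements on the series, on what has been measured and on what is new or still open speak of the compounds shown alone.

Among the compounds with values here, in a functional assay on KARPAS-422 cells (Homo sapiens) for antiproliferative activity, read by resazurin assay, with a stated time of 72 h (a lower number here means a stronger inhibitor, a higher number a weaker inhibitor), compound 2 `Cc1cc(C)c(CN2CCc3c(Cl)cc([C@@H](C)CO)c(Cl)c3C2=O)c(=O)[nH]1` gives 1500 nM, its only number, with one further entry lacking a single value. Compound 1 `COC(c1cc(Cl)c2c(c1Cl)C(=O)N(Cc1c(C)cc(C)[nH]c1=O)CC2)C1CCOCC1` gives 1150 nM; 19 nM (2 entries), two widely separated entries, the higher one level with compound 2. Compound 3 `Cc1cc(C)c(CN2CCc3c(Cl)cc([C@@H](CO)[C@H]4CCCO4)c(Cl)c3C2=O)c(=O)[nH]1` differs from compound 2 by a group of 8 heavy atoms (6 carbon, 2 oxygen; one five-membered non-aromatic ring with 1 hetero atom) in place of a group of 4 heavy atoms (3 carbon, 1 oxygen; no ring), on an aromatic carbon. Within the data shown here, no measured step covers this change, so the expectation rests loosely on the ring-bearing side group of compound 1 at 1150 nM; 19 nM (2 entries): a move towards stronger inhibition in this assay, with a wide margin. The expected step is a 7.5-fold lower number from compound 2 to compound 3 (0.88 log units; beyond the scatter). Compound 3 is estimated at 200 nM, range 30 nM to 1300 nM.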

Compound 3, half-maximal inhibitory concentration: 535 nM
The estimate for compound 3 lay 2.7-fold (0.43 log units) below the measured number; measured number inside the range.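

In this assay, the aromatic carbon para to a fused ring accepts a larger side group carrying a five-membered non-aromatic ring with 1 hetero atom, and the change gives a 2.8-fold lower number from compound 2 to compound 3 (0.45 log units; beyond the scatter). So 1-(hydroxymethyl)ethyl does not mark the upper size limit at this position, and adding the ring does not cost activity here. On these data alone, whether an amine or a carboxylic acid in place of the hydroxyl would hold this gain remains open, as does the contribution of each of the 2 defined stereocentres. How far a ring-bearing side group can take the series also stays unsettled: the several entries of compound 1 in this assay, 1150 nM; 19 nM (2 entries)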